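This account rests on a few compounds, and the source may have more. Where it says the series, first, only, none or still open, it means among the compounds named here.

Working notes on the series. Compound 1 `CC(=O)N[C@@H]1[C@@H](OC(C)=O)[C@H](OC(C)=O)[C@@H](COC(C)=O)O[C@H]1NC(=S)NCCN([C@@H](C(=O)O)C(C)C)S(=O)(=O)c1ccc(-c2ccccc2)cc1` and compound 2 `CO[C@@H]1O[C@H](CN([C@@H](C(=O)O)C(C)C)S(=O)(=O)c2ccc(-c3ccccc3)cc2)[C@@H](O)[C@H](O)[C@H]1NC(C)=O` share the sulfonyl-valine portion and differ in the sugar part. In an assay on isolated protein for inhibition of matrix metalloproteinase-9 (Homo sapiens), read by fluorescence, with stated times of 3 h, 10 s and 15 min (a higher number here means a weaker inhibitor, a lower number a stronger inhibitor), compound 1 gives 1200 nM. In this assay compound 2 gives 890 nM, the lowest of the two numbers recorded, though the gap to compound 1 lies within the scatter of the method, so no order between the two can be read. Compound 3 `CC(=O)N[C@@H]1[C@@H](OC(C)=O)[C@H](OC(C)=O)[C@@H](COC(C)=O)O[C@H]1N([C@@H](C(=O)O)C(C)C)S(=O)(=O)c1ccc(-c2ccccc2)cc1` belongs to the same set; in this assay compound 3 gives "not determined" (no result reported), so no result is available for it.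

Compound 4 `CO[C@@H]1O[C@H](CN([C@@H](C(=O)O)C(C)C)S(=O)(=O)c2ccc(-c3ccccc3)cc2)[C@@H](O)[C@H](O)[C@H]1O` is the next entry to be measured. Relative to compound 2 the change is hydroxy in place of acetamido on a saturated ring carbon. For the measured compounds named here, no pair of measured compounds covers this change, so the step has no precedent. Given that compound 2 gives 890 nM and compound 1, which keeps the acetamido group, gives 1200 nM, the expected step of a 1.6-fold higher number from compound 2 to compound 4 (0.20 log units; within the scatter) is small, at most a modest move toward a higher number. For compound 4 the estimate in this assay is 1400 nM, with a range from 500 nM to 4000 nM.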

Compound 4, half-maximal inhibitory concentration: 2200 nM
For compound 4 the middle estimate is 1.6-fold (0.20 log units) below the measured one; low and high end bracket the measured number.
By their numbers in this assay, from the lowest: compounds 2, 1 and 4 (each within the scatter of the next, the first and the last beyond it).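

Hydroxy in place of acetamido on this saturated ring carbon gives a 2.5-fold higher number from compound 2 to compound 4 (0.39 log units; beyond the scatter) in this assay, the first step in the series that isolates a single place. The acetamido group therefore counts at this position, since its loss moves the number beyond the scatter, yet the step is modest and compound 4 still gives a number on the same scale as compound 2. Nothing available here bears on why the number rises with this change.

From the compounds shown here alone, whether an amine or a longer acyl chain on the nitrogen at this carbon would stand nearer compound 2 or compound 4 remains open. Also open, going by these compounds, is whether the same change would have a step of similar size on the core of compound 1.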